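The source may report more compounds than this note shows. Statements on the series, on what has been measured and on what is new or still open speak of the compounds shown alone.

Measured compounds:

Compound 1 `Cc1c(C(=O)Nc2c(F)cc(-c3cccc(F)c3)cc2F)nc2ccc(F)cc2c1O`; in a functional assay on Hep 3B2 cells (Homo sapiens) for antiproliferative activity, read by MTT assay, with a stated time of 24 h (on this read-out higher numbers stand for weaker inhibition and lower numbers for stronger inhibition), compound 1 gives > 100000 nM, which is a limit of the assay and not a number.
Compound 2 `COc1ccc2nc(C(=O)Nc3ccc(-c4ccccc4)cc3)c(C)c(O)c2c1`; in this assay compound 2 gives 18100 nM.
Compound 3 `Cc1c(C(=O)Nc2c(F)cc(-c3cccc(F)c3)cc2F)nc2ccc(F)cc2c1C(=O)O`; in this assay compound 3 gives 14700 nM.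

Within the data shown here, the one counted change is carboxy in place of hydroxy on an aromatic carbon, which gave an at least 6.8-fold lower number from compound 1 to compound 3 (0.83 log units; beyond the scatter); since compound 1 sits at the limit of > 100000 nM in this assay, at which 1 of the 3 values shown sits, only the lower bound of that step is known. Compound 2 and compound 3 lie within the scatter of each other. How the core of compound 2 differs from that of compound 1 is not broken down here.

Compound 4 `COc1ccc2nc(C(=O)Nc3ccc(-c4ccccc4)cc3)c(C)c(C(=O)O)c2c1` carries the same change on the core of compound 2: carboxy in place of hydroxy on an aromatic carbon. Resting on an at least 6.8-fold lower number from compound 1 to compound 3 (0.83 log units; beyond the scatter), the expected step is a 4.5-fold lower number from compound 2 to compound 4 (0.66 log units; beyond the scatter), with wide uncertainty because the earlier step is bounded only on one side. The estimate for compound 4 in this assay is 4000 nM, spanning 1000 nM to 18000 nM.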

Compound 4, half-maximal inhibitory concentration: 9430 nM
Compound 4: middle estimate off by 2.4-fold (0.37 log units), on the low side; low and high end bracket the measured number.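

Carboxy in place of hydroxy on an aromatic carbon gives a 1.9-fold lower number from compound 2 to compound 4 (0.28 log units; within the scatter) in this assay, so on the core of compound 2 the change has no effect that can be told from the scatter. The change therefore does not carry over at the same size from one core to the other: the same change on two cores in this assay, an at least 6.8-fold lower number (0.83 log units; beyond the scatter) from compound 1 to compound 3 and a 1.9-fold lower number (0.28 log units; within the scatter) from compound 2 to compound 4, at least 3.5-fold (0.54 log units) apart, beyond the scatter of two such steps. As far as these compounds go, compound 1 gives a limit and not a number, so the full size of the earlier step stays unknown, and two cores set no rule for any other core: the limit of > 100000 nM in this assay, at which 1 of the 4 values shown sits.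

Which of the differences between the two cores goes with the gap between the steps remains open. Also open, from the compounds shown here alone, is how a methyl ester or a primary amide would read in place of the carboxy.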